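The source may report more compounds than this note shows. Statements on the series, on what has been measured and on what is new or still open speak of the compounds shown alone.

Measured compounds in a physicochemical assay for lipophilicity; a lower number here means a more polar compound, a higher number a more lipophilic compound:
- compound 1 `C[C@H]1CC[C@@H]2[C@@H](OC(=O)[C@]23CC(c2c(Cl)cccc2Cl)=NO3)[C@]2(C)C(=O)C=C[C@@]12O` gives 2.67
- compound 2 `C[C@H]1CC[C@@H]2[C@@H](OC(=O)[C@]23CC(c2ccccc2Cl)=NO3)[C@]2(C)C(=O)C=C[C@@]12O` gives 2.09

Compound 2 holds the lowest of the two numbers in this assay; its nearest neighbour is compound 1, which stands higher by a margin beyond the scatter. For the measured compounds named here, the one step between the two measured compounds, a number 0.58 log units lower from compound 1 to compound 2 (beyond the scatter), came with hydrogen in place of chloro on an aromatic carbon.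

Compound 3 `C[C@H]1CC[C@@H]2[C@@H](OC(=O)[C@]23CC(c2ccc(F)cc2)=NO3)[C@]2(C)C(=O)C=C[C@@]12O` is not yet measured. It differs from compound 2 in one place: 4-fluorophenyl in place of 2-chlorophenyl on a carbon with a double bond to nitrogen. Going by the values given here, the step that bears on this is the one from compound 1 to compound 2, where a chloro left the aromatic ring and the number in this assay fell by a modest amount beyond the scatter. Here too a chloro leaves, but a fluoro enters in its place, so the step is expected to point the same way and to be somewhat smaller. The step of a number 0.34 log units lower from compound 2 to compound 3 (beyond the scatter) is the estimate that follows. Compound 3 is therefore expected to give 1.75 in this assay, within a range from 1.4 to 2.1.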

Compound 3, partition coefficient: 1.58
Beside the measured number, compound 3's estimate is 0.17 log units above it; measured number inside the range.
By their numbers in this assay, from the lowest: compound 3; then compound 2; then compound 1.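

On the carbon with a double bond to nitrogen, a halogen stays on the aromatic ring in compound 3, yet this assay still falls: 4-fluorophenyl in place of 2-chlorophenyl gives a number 0.51 log units lower from compound 2 to compound 3 (beyond the scatter) and so extends the downward run that the earlier pair had shown only for the loss of a chloro. Across the whole series, 4-fluorophenyl in place of 2,6-dichlorophenyl gives a number 1.09 log units lower from compound 1 to compound 3 (beyond the scatter) and is a large change, so on the shared core this one group alone spans a wide stretch of the read-out, and the three compounds stand in a clear order with 4-fluorophenyl lowest and 2,6-dichlorophenyl highest. The new step changes the halogen and its place on the ring at once, however, so it cannot say how much of the fall belongs to each.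

From the compounds shown here alone, a 4-chlorophenyl or 2-fluorophenyl group would part those two changes, while it stays open where an unsubstituted phenyl, or a ring carrying an amine or a carboxylic acid, would fall on this scale. Nothing in hand explains why the number moves with these changes.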